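Swapping Ethyl for Cyclopropyl in a Two-Compound Series

The source may report more compounds than this note shows. Statements on the series, on what has been measured and on what is new or still open speak of the compounds shown alone.

In a functional assay on MDA-MB-231 cells (Homo sapiens) for inhibition, read by MTT assay, with a stated time of 5 days (a lower number here means a stronger inhibitor, a higher number a weaker inhibitor), compound 1 `Cc1cc(Nc2nc(NCc3ccc(F)cc3F)nc3c2cnn3C2CCOCC2)n[nH]1` gives 2880 nM and compound 2 `CCc1cc(Nc2nc(NCc3ccc(F)cc3F)nc3c2cnn3C2CCOCC2)n[nH]1` gives 2790 nM. For the measured compounds named here, compound 2 therefore stands level with compound 1, the only other number so far, and the two cannot be told apart. The next structure, compound 3 `Fc1ccc(CNc2nc(Nc3cc(C4CC4)[nH]n3)c3cnn(C4CCOCC4)c3n2)c(F)c1`, carries cyclopropyl in place of ethyl on an aromatic carbon. Going by the values given here, one measured step bears on this change, methyl in place of hydrogen on a saturated chain carbon bound to an aromatic carbon. Among the compounds with values here, that step, a 1.0-fold lower number from compound 1 to compound 2 (0.01 log units; within the scatter), is very small, though a single step is thin evidence and no measured compound yet carries a ring at this place. Only a small move is therefore expected in this assay, with no clear direction and nothing beyond the scatter: the estimated step is a 1.1-fold lower number from compound 2 to compound 3 (0.03 log units; within the scatter). For compound 3 the estimated value is 2600 nM, with an expected range from 1200 nM to 5500 nM.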

Compound 3, half-maximal inhibitory concentration: 2560 nM
For compound 3 the middle estimate is 1.0-fold (0.01 log units) above the measured one; the range from low to high includes it.
By their numbers in this assay, from the lowest: compounds 3, 2 and 1 (each within the scatter of the next).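

Cyclopropyl is the first ring at this place, on an aromatic carbon of the five-membered aromatic ring with 2 nitrogen, and in this assay the result is a 1.1-fold lower number from compound 2 to compound 3 (0.04 log units; within the scatter) and a 1.1-fold lower number from compound 1 to compound 3 (0.05 log units; within the scatter) as well. Methyl, ethyl and cyclopropyl therefore cannot be told apart here, so adding a three-membered ring of carbon to this position makes no readable difference to the number in these three compounds. Nothing measured alongside these values offers an explanation for how closely they agree.

Still open, as far as these compounds go, is whether a larger or different group at this place, such as a phenyl ring, a longer chain or an amine, would move the number beyond the scatter. The shared core stays the same in all three compounds, so they cannot show how changes elsewhere would affect the number.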